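The source may hold more compounds than are shown below. What is called first, only, known or untested is meant among the compounds shown, and "the series" means these compounds.

Measured compounds:
compound 1 `N#Cc1cc2c(Oc3ccccc3OCCn3ccc(=O)[nH]c3=O)cccc2[nH]1`: 72000 nM
compound 2 `N#Cc1ccc2c(Oc3ccc(Cl)cc3OCCn3ccc(=O)[nH]c3=O)cccc2c1`: > 100000 nM
compound 3 `N#Cc1ccc2c(Oc3ccc(Cl)cc3OCCn3ccc(=O)[nH]c3=O)cc(Cl)cc2c1`: 20000 nM

The series is read in an ADME assay on MT2 cells (Homo sapiens) for cytotoxicity, read by MTT assay; on this read-out lower numbers stand for higher toxicity in this test and higher numbers for lower toxicity in this test. Compound 1 gives 72000 nM, the highest of the two numbers in this assay. Compound 2 gives > 100000 nM, which is a limit of the assay and not a number. Compound 3 gives 20000 nM. The change from compound 2 to compound 3 is chloro in place of hydrogen on an aromatic carbon. It brings an at least 5.0-fold lower number from compound 2 to compound 3 (0.69 log units; beyond the scatter), and the step can only be bounded from one side because of the limit of > 100000 nM in this assay, at which 1 of the 3 values shown sits. How the core of compound 1 differs from that of compound 2 is not broken down here; the two values simply stand as given, with compound 1 a number and compound 2 a limit.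

Compound 4 `N#Cc1cc2c(Oc3ccccc3OCCn3ccc(=O)[nH]c3=O)cc(Cl)cc2[nH]1` is not yet measured in this assay. It differs from compound 1 by chloro in place of hydrogen on an aromatic carbon, the same change as that from compound 2 to compound 3, made on a different core. Among the compounds with values here, since the one measured instance of this change gave an at least 5.0-fold lower number from compound 2 to compound 3 (0.69 log units; beyond the scatter), a step of similar direction is expected from compound 1, whose value is 72000 nM, to compound 4, i.e. a 5.1-fold lower number from compound 1 to compound 4 (0.71 log units; beyond the scatter). Compound 4 is therefore estimated at 14000 nM in this assay, with a range from 4500 nM to 45000 nM, the width reflecting that this rests on a single bounded step.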

Compound 4, half-maximal cytotoxic concentration: 81000 nM
Estimate against measurement, compound 4: 5.8-fold (0.76 log units) below; measured number outside the range, above it.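

In this assay, chloro in place of hydrogen on an aromatic carbon gives a 1.1-fold higher number from compound 1 to compound 4 (0.05 log units; within the scatter), so on the core of compound 1 this change has no effect that can be told from the scatter. The same change therefore does not carry over at a fixed size from one core to the other, as the two steps differ clearly: the same change on two cores in this assay, an at least 5.0-fold lower number (0.69 log units; beyond the scatter) from compound 2 to compound 3 and a 1.1-fold higher number (0.05 log units; within the scatter) from compound 1 to compound 4, at least 5.6-fold (0.75 log units) apart, beyond the scatter of two such steps. This shows that the outcome of the change depends on the core in this pair of cases, but two pairs give no rule for other cores, they do not show what in the cores causes the difference, and the first step has a bound only on one side: the limit of > 100000 nM in this assay, at which 1 of the 4 values shown sits.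

Going by these compounds, the core of compound 1 and that of compound 2 differ in more than one place, so it remains open which of these differences separates the two outcomes, and a compound changing only one of them would be needed to tell. On these data alone, it also remains open whether fluoro, bromo, methyl or methoxy at the same position would follow the chloro result on each core in this cytotoxicity read-out.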